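Sulfonamide Piperidines in a Cytotoxicity Screen: Fluoropyridinyl Replaces Dimethylphenyl

This account rests on a few compounds, and the source may have more. Where it says the series, first, only, none or still open, it means among the compounds named here.

Measured compounds:
compound 1, `Cc1cc(C)c(S(=O)(=O)N2CCC(N3CCC(O)CC3)CC2)c(C)c1`, > 5000 nM
compound 2, `Cc1ccc(S(=O)(=O)N2CCC(N3CCC(C)CC3)CC2)cc1C`, > 5000 nM
compound 3, `Cc1cc(C)c(S(=O)(=O)NC2CCC(N3CCC(C)CC3)CC2)c(C)c1`, > 5000 nM

The set so far is small and uniform. In an ADME assay on HCT-116 cells (Homo sapiens) for cytotoxicity, read by CellTiter-Glo, with a stated time of 72 h (on this read-out lower numbers stand for stronger inhibition and higher numbers for weaker inhibition), compound 1 gives > 5000 nM, a limit of the assay rather than a number. In this assay compound 3 likewise gives > 5000 nM, again a limit. Compound 2 stands in the same place: in this assay compound 2 gives > 5000 nM, which is a limit and not a measured concentration. Taken together, (the limit of > 5000 nM in this assay, at which 3 of the 3 values shown sit); none of the three compounds shows cytotoxicity within the range the assay can report, and no ordering among them can be drawn.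

The next compound, compound 4, `CC1CCN(C2CCN(S(=O)(=O)c3cccnc3F)CC2)CC1`, differs from compound 2 at a single position: 2-fluoropyridin-3-yl in place of 3,4-dimethylphenyl on a sulfonyl sulfur. The rest of the molecule, the sulfonamide nitrogen in a ring and the piperidine that carries it, is unchanged.

Among the measured compounds shown here, no step between two measured compounds is available to guide an expectation. With every measured compound resting at the limit, compound 4 is expected to stay there as well, with a step that the limit leaves unreadable from compound 2 to compound 4 that amounts to none beyond the scatter. Compound 4 is therefore estimated at 7000 nM, in a range from 3000 nM to 20000 nM.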

Compound 4, half-maximal inhibitory concentration: > 10000 nM
Compound 4: a limit, no number; the forecaster's own chance of this, stated with the estimate: 80%; middle value at least 1.4-fold (0.15 log units) from the limit.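

In this assay compound 4 gives > 10000 nM, which is a limit and not a number. Among the compounds shown here, compound 2 also rests at a limit, so no step from one compound to the other can be read. The compounds shown leave open what concentration, if any, produces half-maximal inhibition for any of them in this assay.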